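Meta-chloro analogue of an oxime-piperazine dopamine ligand

This account rests on a few compounds, and the source may have more. Where it says the series, first, only, none or still open, it means among the compounds named here.

Compound 1 `O/N=C(\CCN1CCN(c2ccccn2)CC1)c1ccccc1`: 4.4 nM
Compound 2 `O/N=C(/CCN1CCN(c2ccccn2)CC1)c1ccccc1`: 21.7 nM
Compound 3 `O/N=C(/CCN1CCN(c2ccccn2)CC1)c1ccccc1Cl`: 25 nM

In a functional assay on HEK293 cells with D(4) dopamine receptor (Homo sapiens) as the target, read by FLIPR (a higher number here means that more compound is needed for the effect, a lower number that less compound is needed), compound 1 gives the lowest of the three numbers. Compound 2 sits at a 4.9-fold higher number from compound 1 to compound 2 (0.69 log units; beyond the scatter), a step that rests on (the fact that compounds 1 and 2 differ only in the configuration as drawn). Compound 3 adds chloro in place of hydrogen on an aromatic carbon and shows a 1.2-fold higher number from compound 2 to compound 3 (0.06 log units; within the scatter).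

Compound 4 `O/N=C(\CCN1CCN(c2ccccn2)CC1)c1cccc(Cl)c1` differs from compound 1 by chloro in place of hydrogen on an aromatic carbon. Among the compounds with values here, the only measured step of the same kind, a 1.2-fold higher number from compound 2 to compound 3 (0.06 log units; within the scatter), lies within the scatter, so no step beyond the scatter is expected in this assay. Compound 4 is therefore estimated at 6 nM, between 2 nM and 18 nM, which is expected to amount to a 1.4-fold higher number from compound 1 to compound 4 (0.13 log units; within the scatter).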

Compound 4, half-maximal effective concentration: 11.9 nM
The estimate for compound 4 lay 2.0-fold (0.30 log units) below the measured number; the measured number falls inside the stated range.
By their numbers in this assay, from the lowest: compound 1; then compounds 4, 2 and 3 (each within the scatter of the next, the first and the last beyond it).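

Chloro in place of hydrogen on an aromatic carbon, meta to a large group, is not silent here: in this assay it brings a 2.7-fold higher number from compound 1 to compound 4 (0.43 log units; beyond the scatter). The earlier compounds had shown this change only as a step within the scatter, so this is the first step of its kind beyond it. Even so, the two steps cannot be told apart: the same change on two cores in this assay, a 1.2-fold higher number (0.06 log units; within the scatter) from compound 2 to compound 3 and a 2.7-fold higher number (0.43 log units; beyond the scatter) from compound 1 to compound 4, 2.3-fold (0.37 log units) apart, within the scatter of two such steps

What the compounds shown leave open is whether fluoro, methoxy or an amine at this place would move the number as chloro does. They also leave open how the same group would behave on the other aromatic carbons of the core of compound 1.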